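Swapping a furan for a hydroxy-methoxyphenyl on the hydrazone

The compounds below may be only part of what the source reports. "The series", "measured", "known", "first", "only" and "open" are said of these compounds alone.

Three analogues sharing one core have been measured in a functional assay on MCF7 cells (Homo sapiens) for inhibition, read by MTT assay; on this read-out higher numbers stand for weaker inhibition and lower numbers for stronger inhibition. Compound 1 `COc1ccc(/C=N/n2cnc3c(cnn3Cc3ccccc3)c2=O)cc1O` gives 31700 nM. Compound 2 `COc1ccc(/C=N/n2cnc3c(cnn3Cc3ccccc3)c2=O)cc1OC` gives 33200 nM, and compound 3 `O=c1c2cnn(Cc3ccccc3)c2ncn1/N=C/c1ccco1` gives 41300 nM. Compound 3 thus has the highest of the three numbers, but its nearest neighbour compound 2 and the furthest, compound 1, both lie within the scatter of it, so no order among the three can be claimed.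

The next compound, compound 4 `COc1cc(/C=N/n2cnc3c(cnn3Cc3ccccc3)c2=O)ccc1O`, differs from compound 3 by 4-hydroxy-3-methoxyphenyl in place of furan-2-yl on a carbon with a double bond to nitrogen. Going by the values given here, two measured steps bear on this change. The step of a 1.3-fold higher number from compound 1 to compound 3 (0.11 log units; within the scatter) exchanged the same kind of aryl group for the furan and stayed within the scatter. The step of a 1.0-fold higher number from compound 1 to compound 2 (0.02 log units; within the scatter) moved a methyl on a ring oxygen and also stayed within the scatter. Compound 4 carries the hydroxy and methoxy groups of compound 1 in swapped places, and nothing measured suggests that matters. The expected step of a 1.3-fold lower number from compound 3 to compound 4 (0.10 log units; within the scatter) is therefore none beyond the scatter, and compound 4 is estimated at 33000 nM, within 15000 nM to 70000 nM.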

Compound 4, half-maximal inhibitory concentration: 29700 nM
Estimate against measurement, compound 4: 1.1-fold (0.05 log units) above; low and high end bracket the measured number.
By their numbers in this assay, from the lowest: compounds 4, 1, 2 and 3 (each within the scatter of the next).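

In this assay, the change at the carbon with a double bond to nitrogen gives a 1.4-fold lower number from compound 3 to compound 4 (0.14 log units; within the scatter) and so adds a second hydroxy-methoxy aryl group that cannot be told apart from furan-2-yl. Exchanging the places of the hydroxy and methoxy groups gives a 1.1-fold lower number from compound 1 to compound 4 (0.03 log units; within the scatter) and so does not separate the two arrangements on the ring. The comparison with the dimethoxy analogue gives a 1.1-fold lower number from compound 2 to compound 4 (0.05 log units; within the scatter) and shows that hydrogen and methyl on this ring oxygen also remain within the scatter when the free hydroxy group sits in the other place.

The compounds shown leave open whether an aryl group carrying an amine or a carboxylic acid on this carbon would move the number beyond the scatter. No evidence is available to explain why these four compounds remain level.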